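The compounds below may be only part of what the source reports. "The series", "measured", "known", "first", "only" and "open" are said of these compounds alone.

Two compounds of the series have been run in a functional assay on HeLa cells (Homo sapiens) for antiproliferative activity, read by MTT assay, with a stated time of 48 h; on this read-out lower numbers stand for stronger inhibition and higher numbers for weaker inhibition. Compound 1 `Fc1ccccc1N1CCN(Cn2nc(-c3ccc4c(c3)OCCO4)oc2=S)CC1` carries 2-fluorophenyl on an amine nitrogen in a ring; in this assay compound 1 gives 37300 nM. Compound 2 `COc1ccc(N2CCN(Cn3nc(-c4ccc5c(c4)OCCO5)oc3=S)CC2)cc1` carries 4-methoxyphenyl at that nitrogen. In this assay compound 2 reaches only the limit > 50000 nM, so for compound 2 a bound and no number is known. For the measured compounds named here, the single measured step, an at least 1.3-fold higher number from compound 1 to compound 2 (0.12 log units; that floor lies within the scatter), has a floor that lies within the scatter; compound 2 sits at the bound that the limit of > 50000 nM in this assay, at which 1 of the 2 values shown sits, records.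

Compound 3 `S=c1oc(-c2ccc3c(c2)OCCO3)nn1CN1CCN(c2ccccn2)CC1` is the next member: pyridin-2-yl in place of 4-methoxyphenyl on an amine nitrogen in a ring. Going by the values given here, no measured step exchanges a carbon-only ring for a ring with one hetero atom at this nitrogen, so no direction can be read from the data. Both values shown are weak, and the floor of the step from compound 1 to compound 2 lies within the scatter. For compound 3 the expectation is therefore a weak number, estimated at 45000 nM with a range of 18000 nM to 110000 nM, with a fair chance that only a limit is returned. The estimated step of an at least 1.1-fold lower number from compound 2 to compound 3 (0.04 log units; that floor lies within the scatter) is expected to stay within the scatter.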

Compound 3, half-maximal inhibitory concentration: 25100 nM
Estimate against measurement, compound 3: 1.8-fold (0.25 log units) above, and the stated range covers the measured number.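

Compound 3 puts a ring with one hetero atom, pyridin-2-yl, on the amine nitrogen in a ring, and it still returns a measured number in this assay. Set against the carbon-only 2-fluorophenyl ring, the exchange gives a 1.5-fold lower number from compound 1 to compound 3 (0.17 log units; within the scatter), so this hetero atom brings no change that can be told from the scatter, and the same holds so far for the exchange that gives an at least 1.9-fold lower number from compound 2 to compound 3 (0.29 log units; that floor lies within the scatter). Compound 2 is held at a limit of the assay, so that second step is known only as a floor: the limit of > 50000 nM in this assay, at which 1 of the 3 values shown sits.

The compounds shown still leave open whether any group on this nitrogen can move the number in this assay beyond the scatter, since all three entries sit in the same weak range and none of the steps among them can be read as a real difference. A non-aromatic group here, such as a longer alkyl chain or a benzyl group, and an aryl ring carrying a carboxylic acid or an amine, would test whether this position responds at all, or whether the shared core alone sets the level.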